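A few compounds are considered here, and "the series" means these few. Any claim that something is new, unique, unknown or untested is made for them only; others in the source may bear on it.

Measured so far:
compound 1, `CCCCC1([C@@H](O)/C=C/C2[C@H](O)CC(=O)[C@@H]2CCCCCCC(=O)O)CCC1` — 0.017 mg/kg
compound 2, `CCCCC1([C@H](O)/C=C/C2CCC(=O)[C@@H]2CCCCCCCCC(=O)OCC)CCC1` — 6.21 mg/kg

Among the compounds with values here, in a functional assay on the whole organism (strain Hartley) for inhibition, with Cavia porcellus as the target, with stated times of 15 min and 2 min (on this read-out lower numbers stand for an effect already at smaller amounts and higher numbers for an effect only at larger amounts of compound), compound 1 gives 0.017 mg/kg, the lowest of the two numbers known; in this assay compound 2 gives 6.21 mg/kg, a far higher number, well beyond the scatter. Compound 3, `CCCCC1([C@@H](O)/C=C/C2CCC(=O)[C@@H]2CCCCCCC(=O)O)CCC1`, has not yet been measured in this assay. It differs from compound 1 in one place: hydrogen in place of hydroxy on a saturated ring carbon. Within the data shown here, no measured pair shows exactly this change. A step to a higher number, beyond the scatter, is expected here, so that compound 3 is estimated at 0.15 mg/kg in this assay, within 0.03 mg/kg to 1 mg/kg, a step of an 8.8-fold higher number from compound 1 to compound 3 (0.95 log units; beyond the scatter).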

Compound 3, dose for half-maximal effect: 0.0139 mg/kg
Compound 3: middle estimate off by 11-fold (1.03 log units), on the high side, and the stated range ends above it.
By their numbers in this assay, from the lowest: compounds 3 and 1 (each within the scatter of the next); then compound 2.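

In this assay, hydrogen in place of hydroxy on a saturated ring carbon gives a 1.2-fold lower number from compound 1 to compound 3 (0.09 log units; within the scatter). Within the data shown here, the low number of compound 1 therefore does not depend on this hydroxy, which the earlier compounds could not show. Nothing measured here explains why the two compounds read alike. The compounds shown leave open how a methoxy group or an amine on this ring carbon would read. They also leave open what an ethyl ester alone, or a longer chain alone, would do on the core of compound 3.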